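Three Measured Compounds and an Expected Fourth

The source may hold more compounds than are shown below. What is called first, only, known or untested is meant among the compounds shown, and "the series" means these compounds.

Compound 1 `O=C(/C=C/c1ccccc1)c1ccc(N2CCN(c3ccc(Cl)c(Cl)c3)CC2)cc1` gives 13.4% in a functional assay on the whole organism (strain Kunming) for inhibition, with Mus musculus as the target, with a stated time of 1 h, at a dose of 40 mg/kg by the oral route; a higher number here means more inhibition at the dose given (going by the name of the read-out), a lower number less inhibition.
Compound 2 `O=C(/C=C/c1ccccc1)c1ccc(N2CCN(c3cccc(Cl)c3)CC2)cc1` gives 14.1%.
Compound 3 `COc1cccc(N2CCN(c3ccc(C(=O)/C=C/c4ccccc4)cc3)CC2)c1` gives 16%.

All three share the same core and differ only in the aromatic group attached to the nitrogen of the six-membered non-aromatic ring. Compound 3 carries the highest number of the three, but the step of a number 2.6 percentage points higher from compound 1 to compound 3 (within the scatter) and the step of a number 1.9 percentage points higher from compound 2 to compound 3 (within the scatter) both stay within the scatter, as does a number 0.7 percentage points higher from compound 1 to compound 2 (within the scatter), so the three compounds cannot be told apart on these numbers.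

Compound 4 `Cc1ccc(N2CCN(c3ccc(C(=O)/C=C/c4ccccc4)cc3)CC2)cc1` continues this series: 4-methylphenyl in place of 3-methoxyphenyl on an amine nitrogen in a ring. The two earlier exchanges of the aromatic group on that ring nitrogen bear directly on this change, and both moved the read-out by amounts within the scatter. A step of similar size in no particular direction is therefore expected, with a number 1 percentage points lower from compound 3 to compound 4 (within the scatter) meaning essentially no change. Compound 4 is estimated at 15%, with a range from 6% to 25%.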

Compound 4, a percentage reported as inhibition, in the whole organism at one dose (the size of the read-out at that dose, not a potency): 2.85%
Compound 4: the middle estimate sits 12.2 percentage points above what was measured; measured number outside the range, below it.
By their numbers in this assay, from the lowest: compound 4; then compounds 1, 2 and 3 (each within the scatter of the next).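

In this assay, the aromatic group on the ring nitrogen now proves able to shift the read-out: putting 4-methylphenyl in place of 3-methoxyphenyl gives a number 13.2 percentage points lower from compound 3 to compound 4 (beyond the scatter). The same holds against the other two groups, with a number 11.3 percentage points lower from compound 2 to compound 4 (beyond the scatter) and a number 10.6 percentage points lower from compound 1 to compound 4 (beyond the scatter), so 4-methylphenyl stands apart from 3-methoxyphenyl, 3-chlorophenyl and 3,4-dichlorophenyl, which could not be told apart among themselves. No measurement at hand accounts for this drop.

As far as these compounds go, whether the drop belongs to the methyl group itself or to where it sits on the aromatic ring stays open, and 3-methylphenyl or 4-methoxyphenyl would separate the two. Also open, from the compounds shown here alone, is how a group such as 4-aminophenyl or 4-carboxyphenyl would behave on that nitrogen.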